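Aryl substituent swap in a weak cytotoxic series

The source may report more compounds than this note shows. Statements on the series, on what has been measured and on what is new or still open speak of the compounds shown alone.

compound 1 `COC(=O)C[C@H]1C[C@@H](O)[C@@H](C)[C@@H](c2ccc(C(C)C)cc2)N1`: "not active" (no number reported), no number reported
compound 2 `COC(=O)C[C@H]1C[C@H](O)[C@@H](C)[C@@H](c2ccc(C(C)C)cc2)N1`: 17100 nM

Among the measured compounds shown here, in a functional assay on MCF7 cells (Homo sapiens) for cytotoxicity, read by MTT assay (a higher number here means a weaker inhibitor, a lower number a stronger inhibitor), compound 2 gives 17100 nM, the only number in the set; compound 1 gives none. The pair is linked by the fact that compounds 1 and 2 differ only in the configuration as drawn. Compound 3 `COC(=O)C[C@H]1C[C@H](O)[C@@H](C)[C@@H](c2ccc(OC)cc2)N1` is not yet measured. It differs from compound 2 by methoxy in place of isopropyl on an aromatic carbon. For the measured compounds named here, no measured step guides this change, so a step near the scatter in either direction is expected, with a slight lean toward weaker: the expected change is a 1.5-fold higher number from compound 2 to compound 3 (0.16 log units; within the scatter). Compound 3 is estimated at 25000 nM, between 8000 nM and 80000 nM.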

Compound 3, half-maximal inhibitory concentration: 5100 nM
For compound 3 the middle estimate is 4.9-fold (0.69 log units) above the measured one; measured number below the stated range.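

In this assay, methoxy in place of isopropyl on an aromatic carbon gives a 3.4-fold lower number from compound 2 to compound 3 (0.53 log units; beyond the scatter), a step beyond the scatter. This aromatic carbon, para to a large group, therefore affects the read-out, and this change moves it toward a stronger inhibitor. Nothing on hand explains the step.

Going by these compounds, whether an amine, a carboxylic acid or a longer alkoxy chain at this carbon would strengthen or weaken the read-out remains open. So does whether the same swap has any effect in the configuration of compound 1.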